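Trifluoromethyl in place of chloro on compound 1

A few compounds are considered here, and "the series" means these few. Any claim that something is new, unique, unknown or untested is made for them only; others in the source may bear on it.

compound 1 `COc1ccc(Cl)cc1C(=O)Nc1ccc(Cl)cc1O` gives 51300 nM
compound 2 `COc1ccc(Cl)cc1C(=O)Nc1cc(Cl)c(Cl)cc1O` gives 2980 nM
compound 3 `COc1ccc(Cl)cc1C(=O)Nc1cc(Br)ccc1O` gives 4090 nM

In a functional assay on HepG2 cells (Homo sapiens) for cytotoxicity, with a stated time of 24 h (on this read-out lower numbers stand for stronger inhibition and higher numbers for weaker inhibition), compound 1 stands highest of the three (51300 nM), well above both compound 3 (4090 nM) and compound 2 (2980 nM). The unmeasured compound 4 `COc1ccc(Cl)cc1C(=O)Nc1ccc(C(F)(F)F)cc1O` keeps the core of compound 1 but carries trifluoromethyl in place of chloro on an aromatic carbon. The new group sits meta to a hydroxy group and para to a large group. For the measured compounds named here, only one measured step bears on this change, and only indirectly. That step (a 17-fold lower number from compound 1 to compound 2 (1.24 log units; beyond the scatter)) is large, but it is a different change, chloro in place of hydrogen on an aromatic carbon. It shows that one change to compound 1 can move the number far. Going by the values given here, no measured step swaps chloro for trifluoromethyl, so the size remains uncertain. The step expected in this assay is a 2.6-fold lower number from compound 1 to compound 4 (0.41 log units; beyond the scatter) and is expected to be smaller than the measured one, towards a lower number. Compound 4 is estimated at 20000 nM (expected range 6000 nM to 60000 nM).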

Compound 4, half-maximal inhibitory concentration: 4910 nM
Compound 4: middle estimate off by 4.1-fold (0.61 log units), on the high side; the measured number lies below the stated range.
By their numbers in this assay, from the lowest: compounds 2, 3 and 4 (each within the scatter of the next); then compound 1.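

In this assay, trifluoromethyl in place of chloro on an aromatic carbon, meta to a hydroxy group and para to a large group, gives a 10-fold lower number from compound 1 to compound 4 (1.02 log units; beyond the scatter) and is a large step. For the compounds shown here, this is the first measured change at this position of compound 1, and it shows that the position itself can move the number far. Going by these compounds alone, until now, the only large single change on record was a 17-fold lower number from compound 1 to compound 2 (1.24 log units; beyond the scatter) at another place on the same ring, so compound 1 now has two single changes that each give a large step.

The compounds shown leave open whether this step is particular to trifluoromethyl, or whether a methyl, a nitrile or an amine at this position would give a similar one. They also leave open what plain hydrogen there would give, and whether the swap would act the same way on compound 2. Nothing measured here accounts for the size of this step.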